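Fluoro Added to a Benzyl Ring: Limits Only So Far

The source may report more compounds than this note shows. Statements on the series, on what has been measured and on what is new or still open speak of the compounds shown alone.

Of the compounds shown here, three have been tested in an assay on isolated protein for inhibition of prostaglandin E2 receptor EP3 subtype (Homo sapiens) (a higher number here means a weaker inhibitor, a lower number a stronger inhibitor), and each returned only a limit rather than a number. Compound 1 `CSc1ccc(OCc2ccc(F)cc2)c(C2=C(c3cccc(C(=O)O)c3)CCC2)c1` gives a limit of < 3170 nM in this assay. Compound 2 `CSc1ccc(OCc2ccccc2)c(C2=C(c3cccc(C(=O)O)c3)CCC2)c1` likewise gives a limit of < 3170 nM. Compound 3 `CS(=O)(=O)c1ccc(OCc2ccc(F)cc2)c(C2=C(c3cccc(C(=O)O)c3)CCC2)c1` also gives a limit of < 3170 nM. Because (the limit of < 3170 nM in this assay, at which 3 of the 3 values shown sit), the two single-place steps cannot be read: the change fluoro in place of hydrogen on an aromatic carbon produced a step that the two limits leave unreadable from compound 2 to compound 1, and the change from compound 1 to compound 3, methylsulfonyl in place of methylsulfanyl on an aromatic carbon, produced a step that the two limits leave unreadable from compound 1 to compound 3. How the cores of compound 2 and compound 3 differ is not broken down here.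

Compound 4 `CS(=O)(=O)c1ccc(OCc2ccc(F)cc2F)c(C2=C(c3cccc(C(=O)O)c3)CCC2)c1` has not yet been measured. It differs from compound 3 by fluoro in place of hydrogen on an aromatic carbon. For the measured compounds named here, this is the same kind of change as the one from compound 2 to compound 1, but the place differs: there the new fluoro sat para to a large group, here it sits ortho to a large group and meta to a fluoro group. The step from compound 3 to compound 4 is expected to be a step that the limit leaves unreadable from compound 3 to compound 4, resting only on the fact that compound 3 already sits at a limit of < 3170 nM in this assay. Compound 4 is therefore estimated at 800 nM, between 100 nM and 3170 nM.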

Compound 4, half-maximal inhibitory concentration: < 3170 nM
Compound 4 ended at the assay's limit; the forecaster's own chance of this, stated with the estimate: 85%; the middle value is on the limit's open side.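

The step from compound 3 to compound 4 cannot be read, and neither can any other step among these compounds, because each carries only a limit and no number: the limit of < 3170 nM in this assay, at which 4 of the 4 values shown sit.

The compounds shown leave open how strongly each one inhibits in this assay, and whether adding a fluoro or replacing methylsulfanyl with methylsulfonyl shifts that strength at all.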